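Methoxy in Place of Hydrogen on Compound 3

A few compounds are considered here, and "the series" means these few. Any claim that something is new, unique, unknown or untested is made for them only; others in the source may bear on it.

In a physicochemical assay for lipophilicity, using the shake flask method, measured as octanol-water partition, at pH 7.4 (on this read-out lower numbers stand for lower lipophilicity and higher numbers for higher lipophilicity), compound 1 (`CC(=O)N[C@H]1[C@H]([C@@H](O)[C@H](O)CNC(=O)c2ccc(Cl)cc2)O[C@@](OCc2ccc(F)cc2)(C(=O)O)C[C@@H]1O`) gives -0.11, compound 2 (`CC(=O)N[C@H]1[C@H]([C@@H](O)[C@H](O)CNC(=O)c2ccc(Cl)cc2)O[C@@](OCc2ccc3ccccc3c2)(C(=O)O)C[C@@H]1O`) gives 0.58 and compound 3 (`CC(=O)N[C@H]1[C@H]([C@@H](O)[C@H](O)CNC(=O)c2ccc(Cl)cc2)O[C@@](OCc2cccc(F)c2F)(C(=O)O)C[C@@H]1O`) gives -0.27. Set against its two neighbours, the series shows a number 0.16 log units lower from compound 1 to compound 3 (within the scatter) and a number 0.85 log units lower from compound 2 to compound 3 (beyond the scatter). Compound 4 (`COCC(=O)N[C@H]1[C@H]([C@@H](O)[C@H](O)CNC(=O)c2ccc(Cl)cc2)O[C@@](OCc2cccc(F)c2F)(C(=O)O)C[C@@H]1O`) carries methoxy in place of hydrogen on a saturated chain carbon bound to a carbonyl carbon, so methyl becomes methoxymethyl: methoxy in place of hydrogen on a saturated chain carbon bound to a carbonyl carbon. For the measured compounds named here, no measured step touches this place, since all of them swap the group on a saturated chain carbon bound to an oxygen. The expectation is therefore cautious: a small downward move, perhaps none beyond the scatter, with an estimated a number 0.13 log units lower from compound 3 to compound 4 (within the scatter). For compound 4 the estimate is -0.4, with an expected range from -0.8 to 0.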

Compound 4, distribution coefficient: 0.06
Compound 4: middle estimate off by 0.46 log units, on the low side; the measured number lies above the stated range.
By their numbers in this assay, from the lowest: compounds 3, 1 and 4 (each within the scatter of the next, the first and the last beyond it); then compound 2.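

In this assay, for the compounds shown here, the change of methyl to methoxymethyl gives a number 0.33 log units higher from compound 3 to compound 4 (beyond the scatter), so this place, on a saturated chain carbon bound to a carbonyl carbon, can move the read-out, something the earlier steps, all made on a saturated chain carbon bound to an oxygen, could not show. The upward direction rests on this single pair. Nothing given here explains that direction. As far as these compounds go, whether an amine, a carboxylic acid or ethoxy at this place would move the number the same way remains open, as does whether methoxy would do so alongside the 4-fluorophenyl of compound 1 or the naphthalen-2-yl of compound 2.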